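Cyano in place of methyl on compound 2

The compounds below may be only part of what the source reports. "The series", "measured", "known", "first", "only" and "open" are said of these compounds alone.

In an ADME assay on microsomes from liver (Homo sapiens) for metabolic stability, with a stated time of 60 min, tested at 1 mg/mL (on this read-out lower numbers stand for slow clearance and higher numbers for fast clearance), compound 1 (`COc1nc2ccc(Br)cc2cc1[C@@H](c1cc(C)c(C)s1)[C@@](O)(CCN(C)C)c1cccc(F)c1`) gives 12 mL.min-1.g-1 and compound 3 (`CCSc1ccc([C@H](c2cc3cc(Br)ccc3nc2OC)[C@@](O)(CCN(C)C)c2cccc(F)c2)cn1`) gives 11 mL.min-1.g-1 while compound 2 (`COc1nc2ccc(Br)cc2cc1[C@@H](c1ccnc(OC)c1OC)[C@@](O)(CCN(C)C)c1cccc(C)c1`) gives 13 mL.min-1.g-1 and so stands within the scatter of both. The unmeasured compound 4 (`COc1nc2ccc(Br)cc2cc1[C@@H](c1ccnc(OC)c1OC)[C@@](O)(CCN(C)C)c1cccc(C#N)c1`) differs from compound 2 by cyano in place of methyl on an aromatic carbon. Among the measured compounds shown here, the only measured step is a 1.1-fold lower number from compound 1 to compound 3 (0.04 log units; within the scatter) and it lies within the scatter. For the measured compounds named here, that step concerns a different group, and no measured step covers this change, so no shift beyond the scatter is expected in this assay here. The expected step is a 1.3-fold lower number from compound 2 to compound 4 (0.11 log units; within the scatter) and it remains an estimate. For compound 4 the estimate is 10 mL.min-1.g-1 within an expected range of 5 mL.min-1.g-1 to 20 mL.min-1.g-1 on this read-out.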

Compound 4, intrinsic clearance in microsomes: 19 mL.min-1.g-1
Compound 4: the middle estimate sits 1.9-fold (0.28 log units) below what was measured; the measured number falls inside the stated range.
By their numbers in this assay, from the lowest: compounds 3, 1, 2 and 4 (each within the scatter of the next).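

In this assay, among the compounds shown here, the exchange of 3-methylphenyl for 3-cyanophenyl gives a 1.5-fold higher number from compound 2 to compound 4 (0.16 log units; within the scatter) and is the first measured step at this position, meta to a large group. Here, on the core of compound 2, methyl and cyano cannot be told apart on this read-out, even though cyano adds a hydrogen-bond acceptor. No measurement shown here offers an explanation for this result. From the compounds shown here alone, it remains open whether an amine or a carboxylic acid at this position would also stay within the scatter. Going by these compounds, whether cyano behaves the same way alongside the 4,5-dimethylthiophen-2-yl group of compound 1 also remains open.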